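A few compounds are considered here, and "the series" means these few. Any claim that something is new, unique, unknown or untested is made for them only; others in the source may bear on it.

Compound 1 `COc1ccc(-n2ccnc2SCC(=O)Nc2ccccc2Cl)cc1`, compound 2 `COc1ccc(-n2ccnc2SCC(=O)Nc2ccccc2F)cc1` and compound 3 `Cc1ccc(-n2ccnc2SCC(=O)Nc2ccccc2Cl)cc1` share one core and differ only in single groups on their two outer rings. In an ADME assay on MT4 cells (Homo sapiens) for cytotoxicity, read by MTT assay (on this read-out higher numbers stand for lower toxicity in this test and lower numbers for higher toxicity in this test), compound 1 gives only a limit of the test, > 334000 nM, and no number. In this assay compound 2 likewise gives only a limit, >= 41900 nM. In this assay, within the data shown here, compound 3 gives 33700 nM, the only number of the three.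

The change from compound 1 to compound 2 is fluoro in place of chloro on an aromatic carbon, and its step, a step that the two limits leave unreadable from compound 1 to compound 2, cannot be sized from two limits. The change from compound 1 to compound 3 is methyl in place of methoxy on an aromatic carbon, giving an at least 9.9-fold lower number from compound 1 to compound 3 (0.99 log units; beyond the scatter).

Compound 4 `Cc1ccc(-n2ccnc2SCC(=O)Nc2ccccc2F)cc1` is not yet measured. It differs from compound 3 by fluoro in place of chloro on an aromatic carbon, the same kind of change as from compound 1 to compound 2, at the same place. Since that earlier step is unreadable, the expectation for compound 4 rests on the value of compound 3, 33700 nM, with a step of about a 1.2-fold higher number from compound 3 to compound 4 (0.07 log units; within the scatter) expected. Compound 4 is therefore estimated to give 40000 nM in this assay, within 15000 nM to 150000 nM.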

Compound 4, half-maximal cytotoxic concentration: 37900 nM
Compound 4: middle estimate off by 1.1-fold (0.02 log units), on the high side; measured number inside the range.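

In this assay, fluoro in place of chloro gives a 1.1-fold higher number from compound 3 to compound 4 (0.05 log units; within the scatter), so with the methyl group present this swap makes no difference that can be told from the usual scatter; the matching step with the methoxy group cannot be read, as both of its ends are limits, so this change cannot be compared across the two cores. Methyl in place of methoxy can be set side by side on two cores, and with fluoro on the ring it gives an at least 1.1-fold lower number from compound 2 to compound 4 (0.04 log units; that floor lies within the scatter), a floor too small to show a real drop. This leaves the pair unsettled, showing neither that the change carries over with the same size nor that its size depends on the core: the same change on two cores in this assay, an at least 9.9-fold lower number (0.99 log units; beyond the scatter) from compound 1 to compound 3 and an at least 1.1-fold lower number (0.04 log units; that floor lies within the scatter) from compound 2 to compound 4; the limit leaves it open whether they differ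

On these data alone, the true numbers behind the limits for compound 1 and compound 2 remain open. Also open, as far as these compounds go, is how this assay would respond to other groups on the two outer rings, such as an amine or a carboxylic acid in place of the methyl or methoxy.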